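The compounds below may be only part of what the source reports. "The series", "measured", "known", "first", "only" and "open" are said of these compounds alone.

Compound 1 `C=CS(=O)(=O)NC/C=C/c1cc(OC)cc(O)c1C(=O)OCc1ccc(Br)cc1` gives 0%
Compound 2 `C=CS(=O)(=O)NC/C=C/c1cc(OC)cc(O)c1C(=O)OCC(C)c1ccccc1` gives 22.5%

Both numbers come from an ADME assay on HEK-293T cells (Homo sapiens) for inhibition, read by luminescence, with a stated time of 72 h, tested at 5 uM (a higher number here means more inhibition of growth at the concentration tested, a lower number less inhibition of growth), and they are the only two at hand. Compound 2 holds the higher of them. Going by the values given here, the one measured step is a number 22.5 percentage points higher from compound 1 to compound 2 (beyond the scatter) and it comes with 1-phenylethyl in place of 4-bromophenyl on a saturated chain carbon bound to an oxygen next to a carbonyl group.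

Compound 3 `C=CS(=O)(=O)NC/C=C/c1cc(OC)cc(O)c1C(=O)OCc1ccc(F)cc1` has not yet been measured. Its difference from compound 2 reads 4-fluorophenyl in place of 1-phenylethyl on a saturated chain carbon bound to an oxygen next to a carbonyl group and it puts 4-fluorophenyl in place of 1-phenylethyl at that same place. The measured step bears directly on this change, since compound 1 also carries a halogen-bearing 4-bromophenyl there and gives 0% in this assay as its reading. No measurement shows how 4-fluorophenyl compares with 4-bromophenyl, so a fall of modest size is expected, perhaps not the full distance back. The expected change is a number 14.5 percentage points lower from compound 2 to compound 3 (beyond the scatter) as an estimate. For compound 3 the estimated value is 8% with an expected range from 0% to 22% in this assay as the read-out.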

Compound 3, percent growth inhibition at one concentration: 0%
Beside the measured number, compound 3's estimate is 8 percentage points above it; the measured number falls inside the stated range.
By their numbers in this assay, from the lowest: compounds 1 and 3 (each within the scatter of the next); then compound 2.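

In this assay, putting 4-fluorophenyl in place of 1-phenylethyl on a saturated chain carbon bound to an oxygen next to a carbonyl group comes with a number 22.5 percentage points lower from compound 2 to compound 3 (beyond the scatter), so a second halogen-bearing group now stands on the low side of compound 2. Fluoro in place of bromo on an aromatic carbon comes with no change at the digits printed from compound 1 to compound 3 (within the scatter), which means that the choice between these two halogens makes no readable difference here, and among the three compounds only compound 2, with 1-phenylethyl, stands apart from the others. Nothing at hand gives a reason for this pattern, and the readings alone cannot supply one.

Compound 2 differs from the other two compounds both in lacking a halogen and in its 2-phenylpropyl chain, so the compounds shown do not tell which of these goes with its higher reading. As far as these compounds go, a plain benzyl group would separate those two differences, while a 2-phenylethyl or 3-phenylpropyl chain would show how the reading follows the chain itself, and whether a halogen on the ring of 2-phenylpropyl lowers it also remains open.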